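A Shorter Chain on the Aromatic Nitrogen: Compound 4

This account rests on a few compounds, and the source may have more. Where it says the series, first, only, none or still open, it means among the compounds named here.

Three compounds sharing one core differ only in the group on the aromatic nitrogen. In an assay on Prostate gland for inhibition of steroid 5-alpha-reductase (Rattus norvegicus) (a higher number here means a weaker inhibitor, a lower number a stronger inhibitor), compound 1 `CCCCCCn1ccc2cc(/C(C)=C/C(=O)Nc3ccccc3OCCCC(=O)O)ccc21` gives 77 nM, compound 2 `CCCC(C(C)C)n1ccc2cc(/C(C)=C/C(=O)Nc3ccccc3OCCCC(=O)O)ccc21` gives 7.2 nM, and compound 3 `CCCCCC(CCCCC)n1ccc2cc(/C(C)=C/C(=O)Nc3ccccc3OCCCC(=O)O)ccc21` gives 25 nM. Compound 3 thus stands second highest of the three: a 3.1-fold lower number from compound 1 to compound 3 (0.49 log units; beyond the scatter), while a 3.5-fold higher number from compound 2 to compound 3 (0.54 log units; beyond the scatter). The step to compound 4 `C/C(=C\C(=O)Nc1ccccc1OCCCC(=O)O)c1ccc2c(ccn2C(C(C)C)C(C)C)c1` is 1-isopropyl-2-methylpropyl in place of 1-pentylhexyl on an aromatic nitrogen. Going by the values given here, two measured steps bear on this: an 11-fold lower number from compound 1 to compound 2 (1.03 log units; beyond the scatter), and a 3.5-fold higher number from compound 2 to compound 3 (0.54 log units; beyond the scatter). The entering 1-isopropyl-2-methylpropyl resembles the 1-isopropylbutyl of compound 2 more than the 1-pentylhexyl of compound 3, so a lower number is expected in this assay, of a size comparable to the reverse of the step from compound 2 to compound 3. In this assay compound 4 is therefore expected to give about 9 nM, with a range from 3.5 nM to 25 nM, which would mean an estimated 2.8-fold lower number from compound 3 to compound 4 (0.44 log units; beyond the scatter).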

Compound 4, half-maximal inhibitory concentration: 14 nM
For compound 4 the middle estimate is 1.6-fold (0.19 log units) below the measured one, and the stated range covers the measured number.
By their numbers in this assay, from the lowest: compounds 2, 4 and 3 (each within the scatter of the next, the first and the last beyond it); then compound 1.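

In this assay replacing 1-pentylhexyl with 1-isopropyl-2-methylpropyl on the aromatic nitrogen gives a 1.8-fold lower number from compound 3 to compound 4 (0.25 log units; within the scatter) while isopropyl in place of propyl on the saturated chain carbon gives a 1.9-fold higher number from compound 2 to compound 4 (0.29 log units; within the scatter) and so compound 4 cannot be separated from either compound. Going by these compounds alone, compound 2 and compound 3 lie beyond the scatter of each other, yet compound 4 falls within the scatter of both, which blurs the difference between these branched groups that the earlier compounds suggested. Against the hexyl of compound 1 the new group still gives a 5.5-fold lower number from compound 1 to compound 4 (0.74 log units; beyond the scatter) and so all three branched groups shown have lower numbers than hexyl, with no compound here going against this.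

The compounds shown leave open how a cyclohexyl ring or a chain ending in an amine on the aromatic nitrogen would compare with these branched chains. Nothing available explains any of these differences.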